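A few compounds are considered here, and "the series" means these few. Any claim that something is new, unique, unknown or untested is made for them only; others in the source may bear on it.

Measured compounds and their numbers in an ADME assay on MT4 cells (Homo sapiens) for cytotoxicity, read by MTT assay; a higher number here means that more compound is tolerated, a lower number that less compound is tolerated:

compound 1, `O=C(CSc1nncnc1-c1ccccc1Cl)Nc1ccccc1`: 127000 nM
compound 2, `O=C(CSc1nncnc1-c1ccccc1Cl)Nc1cccnc1Cl`: 167000 nM
compound 3, `O=C(CSc1nncnc1-c1ccccc1Cl)Nc1ccccc1Br`: 73000 nM

Compound 3 gives the lowest number of the three. Two steps lead to it: a 1.7-fold lower number from compound 1 to compound 3 (0.24 log units; within the scatter) and a 2.3-fold lower number from compound 2 to compound 3 (0.36 log units; beyond the scatter); only the latter separates it clearly.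

Compound 4, `Cc1cnc(NC(=O)CSc2nncnc2-c2ccccc2Cl)c(Br)c1`, is not yet measured in this assay. It differs from compound 3 in one place: 3-bromo-5-methylpyridin-2-yl in place of 2-bromophenyl on an amide-type nitrogen. Among the measured compounds shown here, two measured steps bear on this exchange of a phenyl-type group for a pyridinyl group on the amide-type nitrogen: a 1.3-fold higher number from compound 1 to compound 2 (0.12 log units; within the scatter) and a 2.3-fold lower number from compound 2 to compound 3 (0.36 log units; beyond the scatter). The first shows nothing beyond the scatter; the second is modest and runs in the direction of a higher number when a pyridinyl group sits on that nitrogen. Taken together they suggest that compound 4 is expected to give at most a modest rise relative to compound 3, or no change beyond the scatter.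

Compound 4 is therefore estimated at 105000 nM, with a range from 50000 nM to 220000 nM. This estimate corresponds to an expected step of a 1.4-fold higher number from compound 3 to compound 4 (0.16 log units; within the scatter).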

Compound 4, half-maximal cytotoxic concentration: 144000 nM
Compound 4: the middle estimate sits 1.4-fold (0.14 log units) below what was measured, and the stated range covers the measured number.
By their numbers in this assay, from the lowest: compounds 3, 1, 4 and 2 (each within the scatter of the next, the first and the last beyond it).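

In this assay, 3-bromo-5-methylpyridin-2-yl in place of 2-bromophenyl on the amide-type nitrogen gives a 2.0-fold higher number from compound 3 to compound 4 (0.30 log units; within the scatter) and does not clearly separate the two compounds. The same holds for a 1.2-fold lower number from compound 2 to compound 4 (0.06 log units; within the scatter) and for a 1.1-fold higher number from compound 1 to compound 4 (0.05 log units; within the scatter) as the group is compared with the other two. Compound 4 has a bromo substituent like compound 3 and a pyridinyl ring like compound 2, the only pair shown to separate clearly, yet it lies within the scatter of both. No available measurement accounts for these numbers.

As far as these compounds go, the ring nitrogen and methyl enter together in compound 4, so their separate contributions remain open. Also open, from the compounds shown here alone, is how a carboxylic acid or an amine in place of the bromo would read in this assay on this ring.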